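Naphthalenyl Sulfonamide Against Three Analogues at the Limit

The source may hold more compounds than are shown below. What is called first, only, known or untested is meant among the compounds shown, and "the series" means these compounds.

Compound 1 `Cc1cc(C)c(S(=O)(=O)NC2=NCCN2C(=S)SN2CCn3c2nsc3=S)c(C)c1` sits at the limit of a functional assay on KYSE-510 cells (Homo sapiens) for antiproliferative activity, read by crystal violet staining, with a stated time of 96 h; on this read-out higher numbers stand for weaker inhibition of growth and lower numbers for stronger inhibition of growth. In this assay compound 1 gives >= 20000 nM, which is a limit of the assay and not a number. Compound 2 `COc1cc(C)ccc1S(=O)(=O)NC1=NCCN1C(=S)SN1CCn2c1nsc2=S` gives in this assay >= 20000 nM, likewise a limit. Compound 3 `O=S(=O)(NC1=NCCN1C(=S)SN1CCn2c1nsc2=S)c1ccc(Br)cc1` gives in this assay >= 20000 nM, also a limit. Among the compounds with values here, the steps a step that the two limits leave unreadable from compound 1 to compound 2 and a step that the two limits leave unreadable from compound 1 to compound 3 and a step that the two limits leave unreadable from compound 2 to compound 3 therefore cannot be read, and the only evidence is that the limit of >= 20000 nM in this assay, at which 3 of the 3 values shown sit, holds for every value shown. Compound 4 `O=S(=O)(NC1=NCCN1C(=S)SN1CCn2c1nsc2=S)c1cccc2ccccc12` differs from compound 1 by naphthalen-1-yl in place of 2,4,6-trimethylphenyl on a sulfonyl sulfur. The three measured steps bear on this change only in that each earlier exchange of the group on the sulfonyl sulfur left the value at the limit, so no step beyond the scatter in either direction is expected. Compound 4 is therefore expected to stay at the limit as well, with an estimated step of a number no higher from compound 1 to compound 4 (the limit leaves the size open) and an estimated value of 20000 nM (between 5000 nM and 60000 nM).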

Compound 4, concentration for 50% growth inhibition: >= 20000 nM
Compound 4: a limit, no number (the forecaster's own chance of this, stated with the estimate: 75%); the middle value sits exactly at the limit.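

Within the data shown here, compound 4 also sits at a limit in this assay, so its steps from compound 1, compound 2 and compound 3 cannot be read, and the only evidence is: the limit of >= 20000 nM in this assay, at which 4 of the 4 values shown sit. The compounds shown leave open whether any group on the sulfonyl sulfur gives a readable number.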